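A few compounds are considered here, and "the series" means these few. Any claim that something is new, unique, unknown or untested is made for them only; others in the source may bear on it.

The measured compounds:

compound 1, `N#CC1=C(N)N(c2ccc(S(N)(=O)=O)cc2)C2=C(C(=O)CCC2)C1c1ccc(Cl)cc1Cl`, giving 65% in a functional assay on Ehrlich cells (Mus musculus) for cytotoxicity, read by trypan blue exclusion, with a stated time of 2 h, tested at 50 ug/mL; on this read-out higher numbers stand for a stronger effect at the one concentration tested and lower numbers for a weaker effect
compound 2, `COc1cc(C(=O)NC2=C(C#N)C(c3ccc(Cl)cc3Cl)C3=C(CCCC3=O)N2c2ccc(S(N)(=O)=O)cc2)cc(OC)c1OC`, giving 95% in this assay
compound 3, `NC(=O)C1=C(N)N(c2ccc(S(N)(=O)=O)cc2)C2=C(C(=O)CCC2)C1c1ccc(Cl)cc1Cl`, giving 40% in this assay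

Compound 3 has the lowest of the three numbers. For the measured compounds named here, its nearest neighbour is compound 1, and the one measured step, carbamoyl in place of cyano on a double-bonded ring carbon, reads a number 25 percentage points lower from compound 1 to compound 3 (beyond the scatter), a modest fall beyond the scatter. Going by the values given here, compound 2 sits further above compound 3, but no single-point step links the two, so only their two values can be compared.

Compound 4, `NC1=C(C(=O)O)C(c2ccc(Cl)cc2Cl)C2=C(CCCC2=O)N1c1ccc(S(N)(=O)=O)cc1`, is not yet measured. It differs from compound 3 as follows: hydroxy in place of amino on a carbonyl carbon Put another way, the carbamoyl of compound 3 becomes a carboxy in compound 4. No measured step among these three compounds involves a hydroxy replacing an amino on a carbonyl carbon, so the only step in hand, the one from compound 1 to compound 3, concerns a different change and gives no direct guide. With nothing to point either way, compound 4 is expected to stay close to compound 3, a step of about no change at the digits printed from compound 3 to compound 4 (within the scatter) in this assay, within the scatter. Compound 4 is therefore estimated at 40%, with a wide range from 20% to 60%.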

Compound 4, a percentage reported as activity, at one concentration (the size of the read-out at that concentration, not a potency): 10%
For compound 4 the middle estimate is 30 percentage points above the measured one, outside the stated range (below it).
By their numbers in this assay, from the lowest: compound 4; then compound 3; then compound 1; then compound 2.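

Changing a single atom on this carbonyl carbon matters: in this assay, hydroxy in place of amino gives a number 30 percentage points lower from compound 3 to compound 4 (beyond the scatter), so carbamoyl to carboxy is far from a silent swap. Measured against the nitrile, the carboxy gives a number 55 percentage points lower from compound 1 to compound 4 (beyond the scatter), and the three compounds that differ only on this double-bonded ring carbon now fall in a clear order, with nitrile highest, carbamoyl in the middle and carboxy lowest. Amino and hydroxy each count as one heavy atom and one hydrogen-bond donor, so these simple counts do not separate the two groups, although the read-out does.

Nothing shown here explains why the numbers fall in this order. On these data alone, it also remains open where a methyl ester or an N-methyl amide on the same ring carbon would fall in this order, and whether the order would hold on the core of compound 2 , which gives 95% and carries a trimethoxybenzoyl amide in place of the amino group.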